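Methoxy count on the aryl ring, third methoxy added

A few compounds are considered here, and "the series" means these few. Any claim that something is new, unique, unknown or untested is made for them only; others in the source may bear on it.

Working notes on a small series sharing one core. Compound 1 `CCOC(=O)C12C(=O)OCC=C1COC2c1cccc(Cl)c1` carries a chloro-substituted aryl group; in a functional assay on HeLa cells (Homo sapiens) for cytotoxicity, read by MTT assay (on this read-out lower numbers stand for stronger inhibition and higher numbers for weaker inhibition), compound 1 gives only a limit, > 1000000 nM, which is the limit of > 1000000 nM in this assay, at which 1 of the 3 values shown sits. Compound 2 `CCOC(=O)C12C(=O)OCC=C1COC2c1ccc(OC)cc1` carries one methoxy group on the aryl ring, and in this assay compound 2 gives 18300 nM. Compound 3 `CCOC(=O)C12C(=O)OCC=C1COC2c1ccc(OC)c(OC)c1` carries two methoxy groups, and in this assay compound 3 gives 10000 nM. Between these two numbers the step is a 1.8-fold lower number from compound 2 to compound 3 (0.26 log units; within the scatter), so compound 3 and compound 2 sit within the scatter of each other, while compound 1 sits at a limit.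

Compound 4 `CCOC(=O)C12C(=O)OCC=C1COC2c1cc(OC)c(OC)c(OC)c1` differs from compound 3 by methoxy in place of hydrogen on an aromatic carbon. For the measured compounds named here, the one measured step of the same kind, a 1.8-fold lower number from compound 2 to compound 3 (0.26 log units; within the scatter), stayed within the scatter, so in this assay no step beyond the scatter is expected from compound 3 to compound 4, at most a slight further lowering.

Compound 4 is therefore expected at 7000 nM, within 2500 nM to 20000 nM. The expected step is a 1.4-fold lower number from compound 3 to compound 4 (0.15 log units; within the scatter).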

Compound 4, half-maximal inhibitory concentration: 5400 nM
Estimate against measurement, compound 4: 1.3-fold (0.11 log units) above, and the stated range covers the measured number.
By their numbers in this assay, from the lowest: compounds 4, 3 and 2 (each within the scatter of the next, the first and the last beyond it). At a limit, above all of these: compound 1.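

Methoxy in place of hydrogen on this aromatic carbon, ortho to a methoxy group and meta to a large group, is tolerated in this assay without a step beyond the scatter: a 1.9-fold lower number from compound 3 to compound 4 (0.27 log units; within the scatter). For the compounds shown here, the one earlier step of the same change, a 1.8-fold lower number from compound 2 to compound 3 (0.26 log units; within the scatter), also stayed within the scatter, so the third methoxy group on the aryl ring of compound 4 extends that reading to a second step of this kind, and neither step shows a clear effect of the change. Nothing measured here gives a reason for either step.

From the compounds shown here alone, whether this aromatic carbon accepts anything other than methoxy, such as a hydroxyl group, an amine or a longer alkoxy chain, stays open. Compound 1 gives only a limit, > 1000000 nM, and it differs from the methoxy compounds in more than one place, so it cannot be read against them.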